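The source may hold more compounds than are shown below. What is called first, only, known or untested is meant among the compounds shown, and "the series" means these compounds.

Series notes, amide-nitrogen variation on a shared core, read in a toxicity assay on HepG2 cells (Homo sapiens) for inhibition, read by CellTiter-Glo, with a stated time of 48 h; on this read-out lower numbers stand for stronger inhibition and higher numbers for weaker inhibition:

- compound 1, `COc1ccc2nc(C)cc(OCC(=O)Nc3cc(C)cc(C)c3)c2c1`: 20000 nM
- compound 2, `COc1ccc2nc(C)cc(OCC(=O)Nc3ccc(Cl)cc3Cl)c2c1`: a limit of the assay, > 100000 nM
- compound 3, `COc1ccc2nc(C)cc(OCC(=O)Nc3ccc(F)cc3)c2c1`: 63100 nM

Compound 3 holds the highest of the two numbers given; its nearest neighbour is compound 1, with a 3.2-fold higher number from compound 1 to compound 3 (0.50 log units; beyond the scatter). Compound 2 sits at the limit (the limit of > 100000 nM in this assay, at which 1 of the 3 values shown sits), so the comparison an at least 1.5-fold lower number from compound 2 to compound 3 (0.19 log units; that floor lies within the scatter) rests on a floor only.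

Compound 4, `COc1ccc2nc(C)cc(OCC(=O)NC3CONC3=O)c2c1`, is yet to be measured. The change from compound 3 is a group of 6 heavy atoms (3 carbon, 1 nitrogen, 2 oxygen; one five-membered non-aromatic ring with 2 hetero atoms) in place of a group of 7 heavy atoms (6 carbon, 1 fluorine; one six-membered aromatic ring of carbon only), on an amide-type nitrogen.

Going by the values given here, every measured step so far swaps one substituent on that amide-type nitrogen for another, and the largest, an at least 5.0-fold higher number from compound 1 to compound 2 (0.69 log units; beyond the scatter), is at least modest; none of the three trades a six-membered aromatic ring for a five-membered non-aromatic ring carrying a donor and two acceptors, so no step speaks directly to the change at hand. The swaps already seen moved the number upward from compound 1 whatever the ring, and the new group shares nothing with the 3,5-dimethylphenyl of compound 1. A higher number in this assay is therefore expected for compound 4, with an expected step of about a 1.6-fold higher number from compound 3 to compound 4 (0.20 log units; within the scatter), and the expectation allows that it reaches a limit of the assay. The estimate for compound 4 is 100000 nM, within a range of 30000 nM to 300000 nM.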

Compound 4, half-maximal inhibitory concentration: > 100000 nM
Compound 4 ended at the assay's limit (the forecaster's own chance of this, stated with the estimate: 50%); the middle value lies on the limit itself.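

In this assay compound 4 gives > 100000 nM, which is a limit of the assay and not a number. The results now extend beyond six-membered aromatic rings of carbon only: on this amide-type nitrogen, the five-membered non-aromatic ring with 2 hetero atoms gives an at least 5.0-fold higher number from compound 1 to compound 4 (0.69 log units; beyond the scatter), an at least modest change, and an at least 1.5-fold higher number from compound 3 to compound 4 (0.19 log units; that floor lies within the scatter), so the comparison with the 4-fluorophenyl group remains a floor only. The upper end of the series is now reached by both an aromatic and a non-aromatic group, in compound 2 and compound 4, while compound 1 and compound 3 keep measured numbers, and the step between compound 2 and compound 4 cannot be read: the limit of > 100000 nM in this assay, at which 2 of the 4 values shown sit.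

From the compounds shown here alone, how far compound 4 lies beyond the limit remains open, and with it whether the new ring truly separates it from compound 3. Also open, going by these compounds, is whether an amine, a carboxylic acid or a longer chain on this amide-type nitrogen would stay at the limit or return a measured number.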